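A few compounds are considered here, and "the series" means these few. Any claim that something is new, unique, unknown or untested is made for them only; others in the source may bear on it.

For the measured compounds named here, compound 2 `CCOC(=O)c1c(-c2ccccc2)nn(-c2ccccc2)c1COc1ccc(C=O)cc1OC` gives the higher of the two numbers so far in an assay for inhibition of Alpha amylase (Homo sapiens), with a stated time of 30 min; a lower number here means a stronger inhibitor, a higher number a weaker inhibitor. Its nearest neighbour, compound 1 `CCOC(=O)c1c(-c2ccccc2)nn(-c2ccccc2)c1Cn1c(Cl)nc2ccccc21`, gives 10 ug/mL in this assay, while compound 2 gives 60 ug/mL, and the step of a 6.0-fold higher number from compound 1 to compound 2 (0.78 log units; beyond the scatter) lies beyond the scatter. Compound 3 `CCOC(=O)c1c(-c2ccccc2)nn(-c2ccccc2)c1COCc1ccccc1` has not yet been measured in this assay. It differs from compound 2 by benzyl in place of 4-formyl-2-methoxyphenyl on an oxygen on a saturated carbon, that is, a benzyl in place of 4-formyl-2-methoxyphenyl on an oxygen on a saturated carbon whose other neighbour is a saturated chain carbon. Going by the values given here, only the step from compound 1 to compound 2 touches the same position, and it exchanged a different group, so it gives the scale of what such a change can do there but not its direction. A step of that size in either direction, or none beyond the scatter, is therefore possible. On this basis compound 3 is expected to give about 60 ug/mL in this assay, within a range from 20 ug/mL to 180 ug/mL. This estimate means a step of no change at the digits printed from compound 2 to compound 3 (within the scatter), which is expected to stay within the scatter.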

Compound 3, half-maximal inhibitory concentration: 45 ug/mL
Compound 3: middle estimate off by 1.3-fold (0.12 log units), on the high side; measured number inside the range.
By their numbers in this assay, from the lowest: compound 1; then compounds 3 and 2 (each within the scatter of the next).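

In this assay, benzyl in place of 4-formyl-2-methoxyphenyl on the oxygen gives a 1.3-fold lower number from compound 2 to compound 3 (0.12 log units; within the scatter), so this exchange, which removes the formyl and methoxy groups along with both hydrogen-bond acceptors of the group that leaves, produces no readable difference at this position. The larger gap stays with the other exchange: benzyloxy in place of 2-chloro-1H-benzimidazol-1-yl gives a 4.5-fold higher number from compound 1 to compound 3 (0.65 log units; beyond the scatter), which matches the earlier step in showing compound 1 as the strongest inhibitor of the three, now against two different oxygen-linked groups. No available evidence accounts for either the gap to compound 1 or the absence of a readable difference between compound 2 and compound 3.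

The compounds shown leave open whether an amine, a carboxylic acid or a longer chain in place of benzyl on that oxygen would move the number beyond the scatter. They also leave open whether the advantage of compound 1 depends on its chlorine, since 1H-benzimidazol-1-yl without the chlorine does not appear among them.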